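Dropping one methoxy from the dimethoxyphenyl end of compound 2

The compounds below may be only part of what the source reports. "The series", "measured", "known", "first", "only" and "open" are said of these compounds alone.

Two compounds share a core and differ at the group on the carbonyl carbon. Compound 1 `COc1cc(-c2cc(/C=C/C(=O)c3ccc(N)cc3)[nH]n2)cc(OC)c1OC` carries a 4-aminophenyl there; in a functional assay on HOP-62 cells (Homo sapiens) for cytotoxicity, read by sulforhodamine B assay, with a stated time of 48 h, tested at 10 uM (a higher number here means a weaker effect of the compound at the concentration tested, a lower number a stronger effect), compound 1 gives -59%. Among the measured compounds shown here, compound 2 `COc1ccc(C(=O)/C=C/c2cc(-c3cc(OC)c(OC)c(OC)c3)n[nH]2)cc1OC` carries a 3,4-dimethoxyphenyl instead, and in this assay compound 2 gives -97%, the lowest of the two numbers; the single measured step is a number 38 percentage points lower from compound 1 to compound 2 (beyond the scatter).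

Compound 3 `COc1ccc(C(=O)/C=C/c2cc(-c3cc(OC)c(OC)c(OC)c3)n[nH]2)cc1` is the not-yet-measured partner of compound 2. The change is hydrogen in place of methoxy on an aromatic carbon. For the measured compounds named here, no measured step touches the methoxy groups on this ring; the only step known, from compound 1 to compound 2, exchanged the whole group on the carbonyl carbon and was large. Since the change here is smaller and lacks a precedent, a modest step is expected, with compound 2 as the anchor: a number 12 percentage points higher from compound 2 to compound 3 (beyond the scatter). For compound 3 in this assay the estimate is -85%, within -105% to -45%.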

Compound 3, a percentage reported as activity, at one concentration (the size of the read-out at that concentration, not a potency): -64%
Compound 3: middle estimate off by 21 percentage points, on the low side, and the stated range covers the measured number.
By their numbers in this assay, from the lowest: compound 2; then compounds 3 and 1 (each within the scatter of the next).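

In this assay, the methoxy ortho to a methoxy group on this ring proves to matter a great deal, since replacing it with hydrogen gives a number 33 percentage points higher from compound 2 to compound 3 (beyond the scatter). Going from 3,4-dimethoxyphenyl to 4-methoxyphenyl therefore loses the stronger effect seen with compound 2, and a single methoxy at this position accounts for a large step in this short series. The 4-methoxyphenyl and 4-aminophenyl ends do not separate, as methoxy in place of amino gives a number 5 percentage points lower from compound 1 to compound 3 (within the scatter), and nothing available explains either step.

Still open, from the compounds shown here alone, is whether a hydroxyl or an ethoxy group on the same aromatic carbon would match the methoxy of compound 2. The compounds shown also leave open what happens when the remaining methoxy on this ring is replaced by hydrogen.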